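A few compounds are considered here, and "the series" means these few. Any claim that something is new, unique, unknown or untested is made for them only; others in the source may bear on it.

Measured compounds in an in vitro assay on BTI-TN-5B1-4 cells for inhibition of Amine oxidase [flavin-containing] B (Homo sapiens), read by Amplex Red, with a stated time of 15 min, tested at 100 uM; on this read-out lower numbers stand for less inhibition and higher numbers for more inhibition at the one concentration tested (going by the name of the read-out):

- compound 1 `O=[N+]([O-])c1ccc(-c2csc(N/N=C\c3ccco3)n2)cc1`: 40%
- compound 2 `O=[N+]([O-])c1ccc(-c2csc(N/N=C\c3ccncc3)n2)cc1`: "not active" (no number reported)
- compound 3 `C/C(=C/CC1=CC(c2ccc([N+](=O)[O-])cc2)=CC1)c1ccc2ccccc2c1`: "not active" (no number reported)

Within the data shown here, compound 1 is the only member of the set with a numerical read-out; in this assay compound 1 gives 40%. Compound 2 carries no number and is reported as "not active" (no number reported). Compound 3 stands in the same position: in this assay compound 3 is reported as "not active" (no number reported), with no single value, and it shares this standing with one further entry of the set. The shared core of compound 3 is unrelated to that of compounds 1 and 2, so the two groups give no common reference point.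

Compound 4 `C/C(=C/CC1=CC(c2ccc(F)cc2)=CC1)c1ccc2ccccc2c1` has not yet been run in this assay. It differs from compound 3 in one place: fluoro in place of nitro on an aromatic carbon. Among the measured compounds shown here, no step between measured compounds of this core exists, so the size of the change cannot be read from a comparison. Starting from a compound reported without a number, the expectation is for no step beyond the scatter, in either direction. The estimate for compound 4 in this assay is 10%, with an expected range from 0% to 30%, and a considerable chance that only a qualitative report is returned again.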

Compound 4, a percentage reported as inhibition, at one concentration (the size of the read-out at that concentration, not a potency): 40%
Compound 4: the middle estimate sits 30 percentage points below what was measured; the measured number lies above the stated range.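

Among these compounds, with compound 3 reported without a number in this assay no step from it to compound 4 can be read. The compounds shown leave open how large the change from 4-nitrophenyl to 4-fluorophenyl is on this core. Nothing available bears on this result.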